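A few compounds are considered here, and "the series" means these few. Any claim that something is new, unique, unknown or untested is made for them only; others in the source may bear on it.

Compounds measured in an assay on Prostate gland for inhibition of steroid 5-alpha-reductase (Rattus norvegicus); on this read-out higher numbers stand for weaker inhibition and lower numbers for stronger inhibition:

- compound 1 `CCCC(C)n1ccc2cc(/C(C)=C/C(=O)Nc3ccccc3OCCCC(=O)O)ccc21` gives 7.8 nM
- compound 2 `CCCCCC(CCCCC)n1ccc2cc(/C(C)=C/C(=O)Nc3ccccc3OCCCC(=O)O)ccc21` gives 25 nM
- compound 3 `C/C(=C\C(=O)Nc1ccccc1OCCCC(=O)O)c1ccc2c(ccn2Cc2cccc(C)c2)c1` gives 250 nM

All three share one core and differ only in the group on the aromatic nitrogen. Compound 3 carries a 3-methylbenzyl there and stands at the highest number of the three, that is, it is the weakest inhibitor: the step of a 32-fold higher number from compound 1 to compound 3 (1.51 log units; beyond the scatter) is large and the step of a 10-fold higher number from compound 2 to compound 3 (1.00 log units; beyond the scatter) is modest, both beyond the scatter. The step of a 3.2-fold higher number from compound 1 to compound 2 (0.51 log units; beyond the scatter), between the two alkyl groups, is modest.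

Compound 4 `COc1ccc(Cn2ccc3cc(/C(C)=C/C(=O)Nc4ccccc4OCCCC(=O)O)ccc32)cc1` keeps the benzyl but changes the ring substituent: 4-methoxyphenyl in place of 3-methylphenyl on a saturated chain carbon bound to an aromatic nitrogen. Among the compounds with values here, none of the measured steps compares two benzyl groups with each other; each of them swaps an alkyl chain for another chain or for a benzyl. They therefore give no direct guide for this change, and the expectation in this assay is for a step that stays within the scatter, no change at the digits printed from compound 3 to compound 4 (within the scatter). For compound 4 the estimated value is 250 nM, with a range from 80 nM to 800 nM.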

Compound 4, half-maximal inhibitory concentration: 480 nM
Estimate against measurement, compound 4: 1.9-fold (0.28 log units) below, and the stated range covers the measured number.
By their numbers in this assay, from the lowest: compound 1; then compound 2; then compounds 3 and 4 (each within the scatter of the next).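

In this assay, two benzyl groups can now be compared directly: 4-methoxyphenyl in place of 3-methylphenyl gives a 1.9-fold higher number from compound 3 to compound 4 (0.28 log units; within the scatter) and so does not separate the two compounds, even though the entering group brings an oxygen and a hydrogen-bond acceptor. The wide gaps to the alkyl groups also hold for this second benzyl, with a 19-fold higher number from compound 2 to compound 4 (1.28 log units; beyond the scatter) and a 62-fold higher number from compound 1 to compound 4 (1.79 log units; beyond the scatter) on the same read-out. No measurement here explains why both benzyl compounds give higher numbers than both alkyl compounds.

Compound 3 and compound 4 differ in both the ring substituent and its printed ring number, so 4-methylphenyl or 3-methoxyphenyl would be needed to tell those two changes apart. From the compounds shown here alone, whether an amine or a carboxylic acid on the benzyl ring would shift the number remains open.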